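Swapping Trifluoromethyl for Methoxy on a Nitro Sulfonamide

The source may report more compounds than this note shows. Statements on the series, on what has been measured and on what is new or still open speak of the compounds shown alone.

Compound 1 `Cc1ccc2cccc(NS(=O)(=O)c3ccccc3[N+](=O)[O-])c2n1`: 3800 nM
Compound 2 `Cc1ccc2cccc(NS(=O)(=O)c3ccc(C(F)(F)F)cc3[N+](=O)[O-])c2n1`: 1100 nM

In an assay on isolated protein (HUVEC cells) for inhibition of transcription factor p65 (Homo sapiens) (a lower number here means a stronger inhibitor, a higher number a weaker inhibitor), compound 1 gives 3800 nM and compound 2 gives 1100 nM, so compound 2 holds the lower of the two numbers. Among the measured compounds shown here, the only measured step, a 3.5-fold lower number from compound 1 to compound 2 (0.54 log units; beyond the scatter), shows that the group at this position matters. Compound 3 `COc1ccc(S(=O)(=O)Nc2cccc3ccc(C)nc23)c([N+](=O)[O-])c1` differs by methoxy in place of trifluoromethyl on an aromatic carbon. For the measured compounds named here, no measured step covers methoxy here, so the expected change is uncertain; a modest rise in the number is estimated, a 2.3-fold higher number from compound 2 to compound 3 (0.36 log units; beyond the scatter). Compound 3 is therefore expected to give 2500 nM, with a range from 900 nM to 7000 nM.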

Compound 3, half-maximal inhibitory concentration: 1000 nM
For compound 3 the middle estimate is 2.5-fold (0.40 log units) above the measured one, within the range that was stated.
By their numbers in this assay, from the lowest: compounds 3 and 2 (each within the scatter of the next); then compound 1.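

Methoxy and trifluoromethyl at this position cannot be told apart in this assay (a 1.1-fold lower number from compound 2 to compound 3 (0.04 log units; within the scatter)), although the two groups differ in their atoms and in hydrogen-bond acceptors. Methoxy in place of hydrogen also gives a step beyond the scatter (a 3.8-fold lower number from compound 1 to compound 3 (0.58 log units; beyond the scatter)), so two different groups here both go with a lower number than hydrogen. No evidence bearing on the reason is at hand. From the compounds shown here alone, whether an amine or a carboxylic acid at this position would keep that lower number stays open.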